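The compounds below may be only part of what the source reports. "The series", "measured", "known", "first", "only" and "open" are said of these compounds alone.

Of the compounds shown here, two sharing one core have been measured in a functional assay on NIH3T3 cells (Mus musculus); on this read-out lower numbers stand for an effect already at smaller amounts and higher numbers for an effect only at larger amounts of compound. Compound 1 `COC(=O)[C@H](CCSC)NC(=O)c1ccc(NCc2cncn2Cc2ccc(C#N)cc2)cc1-c1ccccc1` carries a 4-cyanophenyl on a saturated chain carbon bound to an aromatic nitrogen. In this assay compound 1 reaches only a limit of the assay, > 10 uM. Compound 2 `COC(=O)[C@H](CCSC)NC(=O)c1ccc(NCc2cncn2Cc2cccc([N+](=O)[O-])c2)cc1-c1ccccc1` has a 3-nitrophenyl in place of that group. In this assay compound 2 also gives only a limit, > 10 uM. The step that the two limits leave unreadable from compound 1 to compound 2 cannot be sized, as both values sit at the limit of > 10 uM in this assay, at which 2 of the 2 values shown sit. Compound 2 thus stands at a limit, not at a number. Compound 3 `COC(=O)[C@H](CCSC)NC(=O)c1ccc(NCc2cncn2Cc2cccc(Cl)c2)cc1-c1ccccc1` differs from compound 2 by chloro in place of nitro on an aromatic carbon. Within the data shown here, no measured step has a readable size, so nothing points to a change beyond the scatter. The step that the limit leaves unreadable from compound 2 to compound 3 is therefore expected to be small, in either direction. Compound 3 is expected to give 15 uM, between 5 uM and 50 uM, most likely again as a limit.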

Compound 3, concentration for half-maximal effect: > 10 uM
Compound 3: a limit, no number; the forecaster's own chance of this, stated with the estimate: 70%; the middle value lies beyond the limit too.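

Compound 3 also gives only a limit, > 10 uM. Among these compounds, no step among compound 1, compound 2 and compound 3 can be read: the limit of > 10 uM in this assay, at which 3 of the 3 values shown sit. Still open, from the compounds shown here alone, is what real value each compound has in this assay, and whether the 4-cyanophenyl, 3-nitrophenyl and 3-chlorophenyl groups differ at all.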